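Core series at the assay limit: a further side-chain variant

The source may report more compounds than this note shows. Statements on the series, on what has been measured and on what is new or still open speak of the compounds shown alone.

Of the compounds shown here, three of the shared core have so far been measured in an assay on CHO-K1 cells for inhibition of 11-beta-hydroxysteroid dehydrogenase type 2 (Homo sapiens), read by scintillation proximity assay; on this read-out lower numbers stand for stronger inhibition and higher numbers for weaker inhibition. Compound 1 `CCS(=O)(=O)CCC12CCC(c3nnc(-c4ccccc4C)n3C)(CC1)CC2` gives > 4000 nM, which is a limit of the assay rather than a number. Compound 2 `CCS(=O)(=O)CCC12CCC(c3nnc(-c4ccccc4Br)n3C)(CC1)CC2` gives > 4000 nM, again a limit. For the measured compounds named here, the only step between measured compounds that differ in one place, a step that the two limits leave unreadable from compound 1 to compound 2, is therefore not readable from these two values. Compound 3 `Cn1c(-c2ccccc2C(F)(F)F)nnc1C12CCC(CCCC(C)(F)F)(CC1)CC2` gives > 4000 nM, also a limit. Compound 3 thus sits at the limit of > 4000 nM in this assay, at which 3 of the 3 values shown sit, together with the two other compounds, and nothing in the numbers sets it apart from them.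

Compound 4 `CCOCC12CCC(c3nnc(-c4ccccc4C(F)(F)F)n3C)(CC1)CC2` differs from compound 3 by a group of 3 heavy atoms (2 carbon, 1 oxygen; no ring) in place of a group of 6 heavy atoms (4 carbon, 2 fluorine; no ring), on a saturated chain carbon bound to a saturated ring carbon. Going by the values given here, no measured step touches this change, and the single measured step, in a different place, is itself hidden by the limits. The measurements give no direction for compound 4. The step is therefore expected to be a step that the limit leaves unreadable from compound 3 to compound 4, with the most likely outcome that compound 4 again returns only a limit. Compound 4 is accordingly estimated at 8000 nM, within a range of 2000 nM to 40000 nM.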

Compound 4, half-maximal inhibitory concentration: > 4000 nM
Compound 4: only a limit was reported; the forecaster's own chance of this, stated with the estimate: 80%; the middle value does not contradict the limit.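

Compound 4 gives > 4000 nM in this assay, which is a limit and not a number; with compound 3 also held at a limit, no step can be read between compound 3 and compound 4. The compounds shown leave open which change on the shared core would give a readable value in this assay: the limit of > 4000 nM in this assay, at which 4 of the 4 values shown sit.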